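From cyclobutylmethyl to 1-(methoxymethyl)ethyl on an amide-type nitrogen

This account rests on a few compounds, and the source may have more. Where it says the series, first, only, none or still open, it means among the compounds named here.

Compound 1 `O=C(CN(CC1CC1)C(=O)c1ccc(-c2ccccn2)cc1)Nc1cc(F)cc(F)c1`: 5 mL.min-1.g-1
Compound 2 `O=C(CN(CC1CCC1)C(=O)c1ccc(-c2ccccn2)cc1)Nc1cc(F)cc(F)c1`: 4.8 mL.min-1.g-1

In an in vitro ADME assay on microsomes (Rattus norvegicus) for metabolic stability (a higher number here means faster removal of the compound, a lower number slower removal), compound 2 stands level with compound 1, with a 1.0-fold lower number from compound 1 to compound 2 (0.02 log units; within the scatter) lying within the scatter. Compound 3 `COCC(C)N(CC(=O)Nc1cc(F)cc(F)c1)C(=O)c1ccc(-c2ccccn2)cc1` differs from compound 2 by 1-(methoxymethyl)ethyl in place of cyclobutylmethyl on an amide-type nitrogen, which places 1-(methoxymethyl)ethyl in place of cyclobutylmethyl on an amide-type nitrogen. Within the data shown here, the one measured step that bears on this, a 1.0-fold lower number from compound 1 to compound 2 (0.02 log units; within the scatter), exchanged cyclopropyl for cyclobutyl and was small, but no measured compound carries the entering group. No step beyond the scatter is therefore expected in this assay. The expected step is a 1.3-fold higher number from compound 2 to compound 3 (0.10 log units; within the scatter). For compound 3 the estimate is 6 mL.min-1.g-1, with an expected range of 3 mL.min-1.g-1 to 14 mL.min-1.g-1.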

Compound 3, intrinsic clearance in microsomes: 4.2 mL.min-1.g-1
Beside the measured number, compound 3's estimate is 1.4-fold (0.15 log units) above it; the range from low to high includes it.
By their numbers in this assay, from the lowest: compounds 3, 2 and 1 (each within the scatter of the next).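

In this assay, 1-(methoxymethyl)ethyl in place of cyclobutylmethyl on the amide-type nitrogen gives a level result (a 1.1-fold lower number from compound 2 to compound 3 (0.06 log units; within the scatter)), and the same holds against the cyclopropylmethyl of compound 1 (a 1.2-fold lower number from compound 1 to compound 3 (0.08 log units; within the scatter)). Among these compounds, the earlier pair compared only two carbon-only rings, whereas these steps show the number staying level at this position when the ring is lost and an oxygen with one hydrogen-bond acceptor enters. No measurement at hand explains this level result. On these data alone, whether an amine or a carboxylic acid on this chain would also leave the number level remains open.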